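The source may hold more compounds than are shown below. What is called first, only, known or untested is meant among the compounds shown, and "the series" means these compounds.

Measured so far in a functional assay for agonist activity at Melanocyte-stimulating hormone receptor (Homo sapiens), read by cAMP accumulation; on this read-out higher numbers stand for larger maximal responses and lower numbers for smaller maximal responses:

Compound 1, `CC(C)(C)N1C[C@@H](C(=O)Nc2nccn2Cc2cccc(Cl)c2)[C@H](c2ccc(F)cc2F)C1`, gives 50%.
Compound 2, `CC(C)(C)N1C[C@@H](C(=O)Nc2nccn2Cc2ccccc2)[C@H](c2ccc(F)cc2F)C1`, gives 54%.

Compound 2 shows the higher of the two numbers, but the step of a number 4 percentage points higher from compound 1 to compound 2 (within the scatter) lies within the scatter, so the two compounds cannot be told apart on this read-out.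

Compound 3, `CC(C)(C)N1C[C@@H](C(=O)Nc2nccn2Cc2ccccc2-c2ccccc2)[C@H](c2ccc(F)cc2F)C1`, has not yet been measured. Its difference from compound 2 is phenyl in place of hydrogen on an aromatic carbon, a phenyl entering on an aromatic carbon of the six-membered aromatic ring, ortho to a large group.

Going by the values given here, the only measured step, chloro to hydrogen on the same ring, was small and within the scatter, and it does not involve a phenyl or the same position. Among the compounds with values here, no measured step therefore bears directly on this change. The expected step of a number 4 percentage points lower from compound 2 to compound 3 (within the scatter) is none beyond the scatter, with the uncertainty widened for want of a comparable step. Compound 3 is thus estimated at 50%, with a range from 30% to 70%.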

Compound 3, intrinsic activity: the largest response reached, in percent of the reference agonist's: 79%
The estimate for compound 3 lay 29 percentage points below the measured number; the measured number lies above the stated range.
By their numbers in this assay, from the lowest: compounds 1 and 2 (each within the scatter of the next); then compound 3.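

Phenyl on this aromatic carbon, ortho to a large group, brings a number 25 percentage points higher from compound 2 to compound 3 (beyond the scatter) in this assay and so gives the first change in the series that can be told apart on this read-out. The wider exchange of 3-chlorophenyl for 2-phenylphenyl gives a number 29 percentage points higher from compound 1 to compound 3 (beyond the scatter) and also lies beyond the scatter, whereas the earlier loss of chloro could not be told apart. The ring at this end of the molecule can therefore carry a second phenyl ring with a higher maximal response than either earlier compound. No measurement shown bears on why the number rises.

As far as these compounds go, whether a methyl, a methoxy or a pyridyl group on the same carbon would give a similar rise remains open. So does the effect of a phenyl on the other aromatic carbons of this ring.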